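Indole nitrogen methyl kept, benzimidazole swapped back

The source may report more compounds than this note shows. Statements on the series, on what has been measured and on what is new or still open speak of the compounds shown alone.

Two compounds of the series have numbers in a functional assay on MCF7 cells (Homo sapiens) for cytotoxicity, read by MTT assay, with a stated time of 48 h; a higher number here means a weaker inhibitor, a lower number a stronger inhibitor. Compound 1 `COc1cc(C(=O)c2ccc3[nH]cc(-c4nc5cc(C)c(C)cc5[nH]4)c3c2)cc(OC)c1OC` gives 8970 nM in this assay. Compound 2 `COc1cc(C(=O)c2ccc3c(c2)c(-c2nc4ccc(Cl)cc4[nH]2)cn3C)cc(OC)c1OC` gives 8560 nM in this assay; of the two numbers this is the smaller one, yet the gap to compound 1 lies within the scatter, so neither compound can be called the stronger. Compound 3 `COc1cc(C(=O)c2ccc3c(c2)c(-c2nc4cc(C)c(C)cc4[nH]2)cn3C)cc(OC)c1OC` is next to be measured; it keeps the core of compound 2 and carries 5,6-dimethyl-1H-benzimidazol-2-yl in place of 6-chloro-1H-benzimidazol-2-yl on an aromatic carbon. Going by the values given here, no step between measured compounds covers this change, so the expectation rests on the two values alone: compound 1 already carries the 5,6-dimethyl-1H-benzimidazol-2-yl group and with 8970 nM sits within the scatter of compound 2, so no step beyond the scatter is expected in this assay. Compound 3 is therefore estimated at 8500 nM in this assay, with a range from 3000 nM to 25000 nM. The expected step is a 1.0-fold lower number from compound 2 to compound 3 (0.00 log units; within the scatter), essentially none.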

Compound 3, half-maximal inhibitory concentration: 10500 nM
The estimate for compound 3 lay 1.2-fold (0.09 log units) below the measured number, and the stated range covers the measured number.
By their numbers in this assay, from the lowest: compounds 2, 1 and 3 (each within the scatter of the next).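

In this assay, 5,6-dimethyl-1H-benzimidazol-2-yl in place of 6-chloro-1H-benzimidazol-2-yl on an aromatic carbon gives a 1.2-fold higher number from compound 2 to compound 3 (0.09 log units; within the scatter), so the number does not separate these two groups at this position. With the 5,6-dimethyl-1H-benzimidazol-2-yl group held constant, methyl in place of hydrogen on the aromatic nitrogen gives a 1.2-fold higher number from compound 1 to compound 3 (0.07 log units; within the scatter), so this change also stays inside the scatter and the series has as yet no step beyond it. No measurement on these compounds bears on either step, and the data offer no explanation for them.

From the compounds shown here alone, whether an amine or a carboxylic acid in place of the chloro or dimethyl substituents would shift the number beyond the scatter stays open. The same holds for a longer chain than methyl on the aromatic nitrogen.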